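A few compounds are considered here, and "the series" means these few. Any claim that something is new, unique, unknown or untested is made for them only; others in the source may bear on it.

Compound 1 `Cc1cc(C)cc(S(=O)(=O)c2c(C(=O)NC(C)C(=O)NC(C)c3ccccc3)[nH]c3ccc(Cl)cc23)c1` and compound 2 `Cc1cc(C)cc(S(=O)(=O)c2c(C(=O)NCC(=O)NC(C)c3ccccc3F)[nH]c3ccc(Cl)cc23)c1` share a core and have both been run in an ADME assay on MT4 cells (Homo sapiens) for cytotoxicity, read by MTT assay; a lower number here means that less compound is tolerated, a higher number that more compound is tolerated. Compound 1 gives 21700 nM and compound 2 gives 23000 nM; the smaller of the two numbers stands at compound 1, but the gap to compound 2 lies within the scatter, so the two cannot be told apart. Compound 3 `Cc1cc(C)cc(S(=O)(=O)c2c(C(=O)NC(C)c3cc(F)cc(F)c3)[nH]c3ccc(Cl)cc23)c1` has not yet been measured in this assay. It differs from compound 1 in one place: 3,5-difluorophenyl in place of (1-phenylethyl)carbamoyl on a saturated chain carbon bound to an amide-type nitrogen and a saturated chain carbon. Going by the values given here, no step between measured compounds that differ in a single place is available, so the size of the effect of such a change is not known from the data. The two measured values sit close together in spite of their own differences in this region, which gives no sign of a strong dependence on it. The step of a 1.1-fold lower number from compound 1 to compound 3 (0.04 log units; within the scatter) is expected to be none beyond the scatter. The estimate for compound 3 is 20000 nM, with a range from 8000 nM to 50000 nM.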

Compound 3, half-maximal cytotoxic concentration: > 49700 nM
Compound 3 ended at the assay's limit; the forecaster's own chance of this, stated with the estimate: 15%; middle value at least 2.4-fold (0.39 log units) from the limit.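

In this assay, going by these compounds alone, the change to 3,5-difluorophenyl in place of (1-phenylethyl)carbamoyl gives an at least 2.2-fold higher number from compound 1 to compound 3 (0.35 log units; beyond the scatter) and so shows that this place on the saturated chain carbon does matter for how much compound is tolerated, which the earlier compounds gave no sign of. The figure for compound 3 is a limit of the assay and not a number, so the step gives only a minimum size: the limit of > 49700 nM in this assay, at which 1 of the 3 values shown sits. The change takes out a hydrogen-bond donor and a hydrogen-bond acceptor and brings in two fluorine atoms, all in one step, so no single part of it can be credited with the effect.

Going by these compounds, whether the step belongs to the loss of the carbamoyl part or to the two fluorines stays open, and a plain phenyl at this place would separate the two. Also open, on these data alone, is how a carboxylic acid or an amine at this place would read in this assay.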